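A few compounds are considered here, and "the series" means these few. Any claim that something is new, unique, unknown or untested is made for them only; others in the source may bear on it.

Compound 2 `Cc1nc2c3ccccc3ccc2c2nc3c(ccc4ccccc43)c(-c3nccnc3N)c12` gives 134 ug/mL in a functional assay, with a stated time of 90 s (on this read-out higher numbers stand for weaker inhibition and lower numbers for stronger inhibition), the lowest of the two numbers recorded, with compound 1 `Cc1nc2c3ccccc3ccc2c2nc3c(ccc4ccccc43)c(-c3cccc([N+](=O)[O-])c3)c12` nearest at 157 ug/mL; the gap between them lies within the scatter, so no order can be read from it. For the measured compounds named here, the only step measured so far, a 1.2-fold lower number from compound 1 to compound 2 (0.07 log units; within the scatter), exchanged one aryl group for another at the same aromatic carbon and did not move the read-out beyond the scatter. Compound 3 `COc1ccc(-c2c3ccc4ccccc4c3nc3c2c(C)nc2c4ccccc4ccc32)cc1` alters that same position once more: 4-methoxyphenyl in place of 3-aminopyrazin-2-yl on an aromatic carbon. Going by the values given here, since the one step that bears on this position, a 1.2-fold lower number from compound 1 to compound 2 (0.07 log units; within the scatter), stayed within the scatter, no step beyond the scatter is expected in this assay for compound 3, in either direction. Compound 3 is therefore estimated at 140 ug/mL, with a range from 60 ug/mL to 320 ug/mL. The expected step is a 1.0-fold higher number from compound 2 to compound 3 (0.02 log units; within the scatter).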

Compound 3, half-maximal inhibitory concentration: 176 ug/mL
The estimate for compound 3 lay 1.3-fold (0.10 log units) below the measured number; measured number inside the range.
By their numbers in this assay, from the lowest: compounds 2, 1 and 3 (each within the scatter of the next).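

With 4-methoxyphenyl on this aromatic carbon, the read-out in this assay stays within the scatter of both earlier compounds, as shown by a 1.3-fold higher number from compound 2 to compound 3 (0.12 log units; within the scatter) and by a 1.1-fold higher number from compound 1 to compound 3 (0.05 log units; within the scatter). The 3-aminopyrazin-2-yl group carries a hydrogen-bond donor and two ring nitrogens, whereas 4-methoxyphenyl has no hydrogen-bond donor and a ring of carbon only, yet this exchange does not separate the two compounds in this assay. No measurement offers an explanation for this result.

As far as these compounds go, all three compounds carry a six-membered aromatic ring at this position, so the effect of a different kind of group there, such as a simple amine, a carboxylic acid or a longer alkyl chain, remains open. From the compounds shown here alone, it is also open whether any group at this carbon can move the number beyond the scatter.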